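Ring substituent series: ethoxy following ethynyl at one position

The source may hold more compounds than are shown below. What is called first, only, known or untested is meant among the compounds shown, and "the series" means these compounds.

Measured compounds:
compound 1 `CC(C)(C)c1cc(NC(=O)Nc2ccc(-c3cn4ccc(Br)cc4n3)cc2)no1` — in a functional assay on MV4-11 cells (Homo sapiens) for cytotoxicity, read by MTT assay, with a stated time of 72 h (a lower number here means a stronger inhibitor, a higher number a weaker inhibitor), compound 1 gives 9.59 nM
compound 2 `Cc1ccn2cc(-c3ccc(NC(=O)Nc4cc(C(C)(C)C)on4)cc3)nc2c1` — in this assay compound 2 gives 0.79 nM
compound 3 `C#Cc1ccn2cc(-c3ccc(NC(=O)Nc4cc(C(C)(C)C)on4)cc3)nc2c1` — in this assay compound 3 gives 3.46 nM

Compound 3 holds the second highest of the three numbers. Its nearest neighbour is compound 1, the step being a 2.8-fold lower number from compound 1 to compound 3 (0.44 log units; beyond the scatter); its furthest is compound 2, with a 4.4-fold higher number from compound 2 to compound 3 (0.64 log units; beyond the scatter). The remaining measured step, a 12-fold lower number from compound 1 to compound 2 (1.08 log units; beyond the scatter), is the largest in the set. All three steps swap a single group at the same aromatic carbon of the shared core, so this position clearly admits substantial changes in the number.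

Compound 4 `CCOc1ccn2cc(-c3ccc(NC(=O)Nc4cc(C(C)(C)C)on4)cc3)nc2c1` differs from compound 3 in one place: ethoxy in place of ethynyl on an aromatic carbon. Within the data shown here, no measured step involves ethoxy, so no step bears on it directly; the three measured steps only show that exchanges at this carbon have ranged from modest to large. The ethoxy group is expected to land near the middle of the measured spread, so in this assay compound 4 is estimated at 3 nM, with a range from 0.8 nM to 12 nM. The expected step is therefore a 1.2-fold lower number from compound 3 to compound 4 (0.06 log units; within the scatter), not clearly beyond the scatter in either direction.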

Compound 4, half-maximal inhibitory concentration: 11.6 nM
Estimate against measurement, compound 4: 3.9-fold (0.59 log units) below; measured number inside the range.
By their numbers in this assay, from the lowest: compound 2; then compound 3; then compounds 1 and 4 (each within the scatter of the next).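

In this assay, among these compounds, ethoxy at this carbon, opposite the ring nitrogen, does not hold the level of ethynyl: the exchange gives a 3.4-fold higher number from compound 3 to compound 4 (0.53 log units; beyond the scatter), so this is the first oxygen-linked group, and it does not improve on the alkyne. Measured against methyl, the same position shows a 15-fold higher number from compound 2 to compound 4 (1.17 log units; beyond the scatter), a large step of the same order as the one from bromo to methyl, which confirms that methyl stands clearly apart from the three other groups, with compound 2 beyond the scatter of each of the other compounds. Against bromo the exchange gives a 1.2-fold higher number from compound 1 to compound 4 (0.08 log units; within the scatter), so ethoxy and bromo cannot be told apart here, and two very different groups now share the weak end of the range while ethynyl sits between them and methyl.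

No measurement shown here accounts for the separation of methyl from ethoxy, or for the parity of ethoxy with bromo. Going by these compounds, it remains open whether methoxy, an ethyl chain, a longer chain such as propyl, or an amine at this carbon would fall with methyl or with ethoxy and bromo.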